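Lengthening the chain of a stomach-active thioamide

This account rests on a few compounds, and the source may have more. Where it says the series, first, only, none or still open, it means among the compounds named here.

The measured compounds, with their values in this assay:
compound 1, `CC/N=C(\S)CCn1nc(-c2ccccc2)ccc1=O`, gives 100 mg/kg;
compound 2, `Cc1ccc(=S)n(CCC(=N)S)n1`, gives 100 mg/kg;
compound 3, `N=C(S)CCn1nc(-c2ccc(Cl)cc2)ccc1=O`, reaches only the limit > 100 mg/kg.

The read-out is a functional assay on the whole organism (stomach) with Rattus norvegicus as the target; a lower number here means that less compound is needed, a higher number that more compound is needed for the effect. Compound 1 gives 100 mg/kg, and compound 2 gives 100 mg/kg, the same at the digits shown, so nothing separates the two within the scatter. Compound 3 does not give a number here, only a limit; that limit is the limit of > 100 mg/kg in this assay, at which 1 of the 3 values shown sits. Among the compounds with values here, compound 1 therefore stands level with the only other compound that has a number, and one of the three values is a limit rather than a measurement.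

The compound that remains to be measured is compound 4, `N=C(S)CCCCCCn1nc(-c2ccccc2)ccc1=O`. It differs from compound 1 in one place: a group of 7 heavy atoms (5 carbon, 1 nitrogen, 1 sulfur; no ring) in place of a group of 5 heavy atoms (3 carbon, 1 nitrogen, 1 sulfur; no ring), on a saturated chain carbon, two bonds along the chain from an aromatic nitrogen. Within the data shown here, no pair of measured compounds differs in a single place, so there is no measured step to say how large an effect such a change has had in this assay. With nothing to point either way, the expectation is a step of about no size beyond the scatter, no change at the digits printed from compound 1 to compound 4 (within the scatter). The estimate for compound 4 in this assay is 100 mg/kg, expected to fall between 50 mg/kg and 300 mg/kg.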

Compound 4, dose for half-maximal effect: > 100 mg/kg
Compound 4: only a limit was reported; the forecaster's own chance of this, stated with the estimate: 40%; the middle value lies on the limit itself.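

In this assay compound 4 gives only a limit, > 100 mg/kg. Within the data shown here, putting a group of 7 heavy atoms (5 carbon, 1 nitrogen, 1 sulfur; no ring) in place of a group of 5 heavy atoms (3 carbon, 1 nitrogen, 1 sulfur; no ring), on a saturated chain carbon, two bonds along the chain from an aromatic nitrogen, gives a number no lower from compound 1 to compound 4 (the limit leaves the size open), so this change did not lower the dose needed, which the earlier compounds, none of them differing from another in a single place, could not show. This first single-place comparison also ends at a limit rather than at a second number, and limits now make up a larger share of the small set: the limit of > 100 mg/kg in this assay, at which 2 of the 4 values shown sit.

The size of the step stays unread, and since the whole group changes at once, the compounds shown cannot separate the effect of the longer chain from that of the other differences between the two groups. They also leave open what this position would give with a carboxylic acid or an amine at the end of the chain in place of the thioamide.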